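A few compounds are considered here, and "the series" means these few. Any claim that something is new, unique, unknown or untested is made for them only; others in the source may bear on it.

In a functional assay on HepG2 cells (Homo sapiens) for antiproliferative activity, read by MTT assay, with a stated time of 48 h (on this read-out lower numbers stand for stronger inhibition and higher numbers for weaker inhibition), compound 3 `COc1ccc(/C=C/c2cc(OC)cc(OC)c2/C=C/C(=O)c2cccc(Br)c2)cc1` gives 13 ug/mL. That lies within the scatter of compound 1 `COc1ccc(/C=C/c2cc(OC)cc(OC)c2/C=C/C(=O)c2cccc(OC)c2)cc1` at 11.6 ug/mL, while compound 2 `COc1ccc(/C=C/c2cc(OC)cc(OC)c2/C=C/C(=O)c2ccc(C)cc2)cc1` gives a clearly lower 4.8 ug/mL. Compound 4 `COc1ccc(/C=C/c2cc(OC)cc(OC)c2/C=C/C(=O)c2cccc(Cl)c2)cc1` differs from compound 3 by one swap, chloro in place of bromo on an aromatic carbon. Among the measured compounds shown here, no measured step makes this exact swap. The closest is a 1.1-fold higher number from compound 1 to compound 3 (0.05 log units; within the scatter), where bromo replaces methoxy on an aromatic carbon, and it stayed within the scatter. The larger steps, a 2.4-fold lower number from compound 1 to compound 2 (0.38 log units; beyond the scatter) and a 2.7-fold higher number from compound 2 to compound 3 (0.43 log units; beyond the scatter), both involve the 4-methylphenyl group, which is not part of this swap. No change beyond the scatter is therefore expected in this assay. The expected step is a 1.1-fold lower number from compound 3 to compound 4 (0.03 log units; within the scatter). For compound 4 the estimated value is 12 ug/mL, with an expected range of 6 ug/mL to 22 ug/mL.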

Compound 4, half-maximal inhibitory concentration: 9.5 ug/mL
Estimate against measurement, compound 4: 1.3-fold (0.10 log units) above; the measured number falls inside the stated range.
By their numbers in this assay, from the lowest: compounds 2, 4, 1 and 3 (each within the scatter of the next, the first and the last beyond it).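

In this assay chloro for bromo on this aromatic carbon gives a 1.4-fold lower number from compound 3 to compound 4 (0.14 log units; within the scatter) and chloro for methoxy gives a 1.2-fold lower number from compound 1 to compound 4 (0.09 log units; within the scatter) so all three groups now read alike here. The 3-chlorophenyl group also stays close to the 4-methylphenyl group of compound 2, with a 2.0-fold higher number from compound 2 to compound 4 (0.30 log units; within the scatter) even though 3-bromophenyl stood clearly apart from it. No measurement shown explains these results. On these data alone, whether an amine or a carboxylic acid on this carbon would also read alike remains open.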